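A few compounds are considered here, and "the series" means these few. Any claim that something is new, unique, unknown or untested is made for them only; others in the source may bear on it.

Compound 1 `O=C(Nc1cccc(-n2cc(-c3ccncc3)c(-c3ccc(Cl)c(O)c3)n2)c1)Nc1cccc(C(F)(F)F)c1`: in a functional assay on HOP-62 cells (Homo sapiens) for inhibition, read by sulforhodamine B assay, with a stated time of 48 h (a higher number here means that more compound is tolerated, a lower number that less compound is tolerated), compound 1 gives > 32500 nM, which is a limit of the assay and not a number.
Compound 2 `COc1cc(-c2nn(-c3cccc(NC(=O)c4cccc(C(F)(F)F)c4)c3)cc2-c2ccncc2)ccc1Cl`: compound 2 gives > 50000 nM, again a limit.
Compound 3 `COc1cc(-c2nn(-c3cccc(NC(=O)c4ccc(Cl)c(C(F)(F)F)c4)c3)cc2-c2ccncc2)ccc1Cl`: compound 3 gives > 32500 nM, also a limit.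

Compound 2 therefore stands nowhere on a scale of numbers: its value is a limit, as are the two others shown beside it. Two of the three values sit at the limit of > 32500 nM in this assay, at which 2 of the 3 values shown sit, and one at the limit of > 50000 nM in this assay, at which 1 of the 3 values shown sits. For the measured compounds named here, the only step between measured compounds that differ in one place, a step that the two limits leave unreadable from compound 2 to compound 3, cannot be read for size, since both of its ends are limits.

Compound 4 `COc1cc(-c2nn(-c3cccc(NC(=O)c4ccccc4)c3)cc2-c2ccncc2)ccc1Cl` differs from compound 2 by hydrogen in place of trifluoromethyl on an aromatic carbon. Going by the values given here, no measured step bears on this change in a readable way, so no size can be carried over from the measured compounds. What the three values do show is that none of them reached a number in this assay, and compound 4 is expected to behave in the same way. The step from compound 2 to compound 4 is expected to be an at least 1.1-fold lower number from compound 2 to compound 4 (0.04 log units; that floor lies within the scatter), that is, nothing beyond the scatter. Compound 4 is accordingly estimated at 45000 nM, with a range from 12000 nM to 120000 nM, and most likely reported only as a limit.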

Compound 4, concentration lethal to 50% of the cells: > 100000 nM
Compound 4: only a limit was reported; the forecaster's own chance of this, stated with the estimate: 85%; middle value at least 2.2-fold (0.34 log units) from the limit.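

In this assay compound 4 gives > 100000 nM, again a limit and not a number. Neither the step from compound 2 to compound 4 nor the step from compound 3 to compound 4 can be read for size: both ends of each are limits. The compounds shown leave open whether hydrogen in place of trifluoromethyl changes the value at all: all four values are limits.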